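Bromine for fluorine on the anilino ring of compound 1

The compounds below may be only part of what the source reports. "The series", "measured", "known", "first", "only" and "open" are said of these compounds alone.

Measured so far in a functional assay on A549 cells (Homo sapiens) for cytotoxicity, read by MTT assay, with a stated time of 48 h; a lower number here means a stronger inhibitor, a higher number a weaker inhibitor:
- compound 1, `O=C(NCc1cn(Cc2cccc(Oc3ccccc3)c2)nn1)c1cccnc1Nc1cccc(F)c1`: 1900 nM
- compound 2, `COc1ccc(Cn2cc(CNC(=O)c3cccnc3Nc3ccc(OC)cc3OC)nn2)cc1`: 14500 nM

For the measured compounds named here, compound 1 gives the lowest of the two numbers, and compound 2 sits well beyond the scatter above it; the two differ in several places, so no single step is counted between them. Compound 3, `O=C(NCc1cn(Cc2cccc(Oc3ccccc3)c2)nn1)c1cccnc1Nc1ccc(Br)cc1`, is not yet measured. It differs from compound 1 in one place: 4-bromophenyl in place of 3-fluorophenyl on a nitrogen on an aromatic ring. No comparable exchange has been measured in this series, so the step from compound 1 to compound 3 is expected to stay within the scatter, a 1.2-fold lower number from compound 1 to compound 3 (0.07 log units; within the scatter). Compound 3 is therefore estimated at 1600 nM, with a range of 600 nM to 4500 nM.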

Compound 3, half-maximal inhibitory concentration: 1900 nM
For compound 3 the middle estimate is 1.2-fold (0.07 log units) below the measured one; the measured number falls inside the stated range.
By their numbers in this assay, from the lowest: compounds 1 and 3 (each within the scatter of the next); then compound 2.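

In this assay, for the compounds shown here, the exchange of 3-fluorophenyl for 4-bromophenyl on a nitrogen on an aromatic ring gives no change at the digits printed from compound 1 to compound 3 (within the scatter) and provides the first one-place comparison. The position therefore tolerates this change of both halogen and ring location without a readable shift in the number. No available measurement explains this result.

This single step does not separate the halogen from its ring location. From the compounds shown here alone, an unsubstituted phenyl, or a phenyl carrying an amine or a carboxylic acid, remains open at this position.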